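The source may hold more compounds than are shown below. What is called first, only, known or untested is meant among the compounds shown, and "the series" means these compounds.

Working notes on the series. All three measured compounds share one core, differing only on the saturated chain carbon bound to an aromatic carbon: compound 1 `COc1cccc(Sc2c(NS(=O)(=O)c3ccc(C(C)(C)C)cc3)noc2C)c1` carries hydrogen there, compound 2 `COc1cccc(Sc2c(NS(=O)(=O)c3ccc(C(C)(C)C)cc3)noc2CCO)c1` hydroxymethyl, compound 3 `COc1cccc(Sc2c(NS(=O)(=O)c3ccc(C(C)(C)C)cc3)noc2CO)c1` hydroxy. In an assay on A7R5 cells for displacement of a labelled ligand from Endothelin-1 receptor (Rattus norvegicus) (on this read-out higher numbers stand for weaker inhibition and lower numbers for stronger inhibition), compound 1 gives 530 nM and compound 2 gives 770 nM; compound 3 gives 6200 nM, the highest of the three numbers. The step of a 1.5-fold higher number from compound 1 to compound 2 (0.16 log units; within the scatter) stays within the scatter, whereas a 12-fold higher number from compound 1 to compound 3 (1.07 log units; beyond the scatter) and an 8.1-fold higher number from compound 2 to compound 3 (0.91 log units; beyond the scatter) both lie beyond it.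

Compound 4 `COc1cccc(Sc2c(NS(=O)(=O)c3ccc(C(C)(C)C)cc3)noc2CCCC(C)=O)c1` differs from compound 3 by 2-acetylethyl in place of hydroxy on a saturated chain carbon bound to an aromatic carbon. Going by the values given here, the change removes the hydroxy that distinguishes compound 3 from compound 1, so the steps that bear on it are a 12-fold higher number from compound 1 to compound 3 (1.07 log units; beyond the scatter) and an 8.1-fold higher number from compound 2 to compound 3 (0.91 log units; beyond the scatter), both beyond the scatter. A return toward the numbers of compound 1 and compound 2 is therefore expected, and the step is estimated at a 7.8-fold lower number from compound 3 to compound 4 (0.89 log units; beyond the scatter). Compound 4 is expected to give about 800 nM in this assay, with a range from 250 nM to 2600 nM.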

Compound 4, half-maximal inhibitory concentration: 1300 nM
For compound 4 the middle estimate is 1.6-fold (0.21 log units) below the measured one, within the range that was stated.
By their numbers in this assay, from the lowest: compounds 1, 2 and 4 (each within the scatter of the next, the first and the last beyond it); then compound 3.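

In this assay, 2-acetylethyl in place of hydroxy on this saturated chain carbon gives a 4.8-fold lower number from compound 3 to compound 4 (0.68 log units; beyond the scatter), so the loss seen with compound 3 does not extend to every oxygen-bearing group here, and this carbon accepts a much larger group than hydroxy. Compound 4 stands level with the hydroxymethyl-bearing chain of compound 2, with a 1.7-fold higher number from compound 2 to compound 4 (0.23 log units; within the scatter), but it does not fully match the hydrogen of compound 1, with a 2.5-fold higher number from compound 1 to compound 4 (0.39 log units; beyond the scatter), which is a modest cost for the added chain. No measured evidence on these compounds accounts for these differences.

As far as these compounds go, whether the carbonyl of 2-acetylethyl matters, or the chain length alone, remains open, as an all-carbon chain such as butyl would separate the two. How an amine or a carboxylic acid at the chain end would compare also remains unresolved.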